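A longer hydroxyalkyl chain on the amide carbonyl

The source may report more compounds than this note shows. Statements on the series, on what has been measured and on what is new or still open speak of the compounds shown alone.

Three compounds share one core and differ only in the group attached to the amide carbonyl. In an assay on cells for positive allosteric modulation of Cystic fibrosis transmembrane conductance regulator variant G551D (Homo sapiens), with stated times of 10 min and 2 min, in the presence of a further agent that is not named here (a lower number here means that less compound is needed, a higher number that more compound is needed for the effect), compound 1 `CC1(C)Cc2c(sc(NC(=O)c3ccccc3O)c2C(N)=O)C(C)(C)O1` gives 162 nM, compound 2 `CC1(C)Cc2c(sc(NC(=O)c3ccn[nH]3)c2C(N)=O)C(C)(C)O1` gives 339 nM, and compound 3 `CC1(C)Cc2c(sc(NC(=O)[C@@H](O)C(C)(C)C)c2C(N)=O)C(C)(C)O1` gives 421 nM, the highest of the three numbers. The steps of a 2.1-fold higher number from compound 1 to compound 2 (0.32 log units; beyond the scatter) and a 2.6-fold higher number from compound 1 to compound 3 (0.41 log units; beyond the scatter) are modest, while a 1.2-fold higher number from compound 2 to compound 3 (0.09 log units; within the scatter) stays within the scatter. Compound 4 `CC(C)(C)CC(O)C(=O)Nc1sc2c(c1C(N)=O)CC(C)(C)OC2(C)C` alters compound 3 by a group of 7 heavy atoms (6 carbon, 1 oxygen; no ring) in place of a group of 6 heavy atoms (5 carbon, 1 oxygen; no ring), on a carbonyl carbon, so one hydroxyalkyl chain replaces another. For the measured compounds named here, of the measured steps, only the one from compound 2 to compound 3 resembles such a small swap, and it stayed within the scatter, so in this assay no step beyond the scatter is expected: a 1.2-fold higher number from compound 3 to compound 4 (0.07 log units; within the scatter). Compound 4 is therefore estimated at 500 nM, with a range from 220 nM to 1100 nM.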

Compound 4, half-maximal effective concentration: 981 nM
For compound 4 the middle estimate is 2.0-fold (0.29 log units) below the measured one; low and high end bracket the measured number.
By their numbers in this assay, from the lowest: compound 1; then compounds 2 and 3 (each within the scatter of the next); then compound 4.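

Swapping one open hydroxyalkyl chain for another on this carbonyl carbon is enough to shift the number, with a 2.3-fold higher number from compound 3 to compound 4 (0.37 log units; beyond the scatter). The new chain also gives a higher number than either ring-bearing group, with a 2.9-fold higher number from compound 2 to compound 4 (0.46 log units; beyond the scatter) and a 6.1-fold higher number from compound 1 to compound 4 (0.78 log units; beyond the scatter), so among these four compounds the 2-hydroxyphenyl group keeps the lowest number. Nothing available here explains these shifts. On these data alone, whether the hydroxyl matters on these chains remains open. So does the effect of an amine or a carboxylic acid on the same chain.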